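The compounds below may be only part of what the source reports. "The series", "measured", "known", "first", "only" and "open" are said of these compounds alone.

Measured compounds:
compound 1, `c1ccc(C(C2Cc3ccccc3O2)n2cncn2)cc1`, with 85.7%
compound 2, `Cc1ccc(C(C2Cc3ccccc3O2)n2cncn2)cc1`, with 96.8%

In an assay for inhibition of Aromatase (Homo sapiens), tested at 20 uM (a higher number here means more inhibition at the concentration tested (going by the name of the read-out), a lower number less inhibition), compound 1 gives 85.7% and stands lowest of the two numbers. Its nearest neighbour, compound 2, gives 96.8%, and the step of a number 11.1 percentage points higher from compound 1 to compound 2 (beyond the scatter) is a modest rise beyond the scatter. Compound 3, `c1ccc(C(C2Cc3ccccc3O2)n2cnnn2)cc1`, is not yet measured. Its change from compound 1 is 1H-tetrazol-1-yl in place of 1H-1,2,4-triazol-1-yl on a saturated chain carbon bound to an aromatic carbon and a saturated ring carbon. Among the measured compounds shown here, the one measured step concerns a methyl on an aromatic carbon and leaves the five-membered ring untouched, so no measured step bears directly on this exchange. With nothing in the numbers to lean on, only a small move can be expected, and the expectation leans toward a decrease, giving an expected step of a number 15.7 percentage points lower from compound 1 to compound 3 (beyond the scatter). Compound 3 is therefore estimated at 70%, with a range from 40% to 95%.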

Compound 3, a percentage reported as inhibition, at one concentration (the size of the read-out at that concentration, not a potency): 35%
Beside the measured number, compound 3's estimate is 35 percentage points above it; the whole stated range lies above it.
By their numbers in this assay, from the lowest: compound 3; then compound 1; then compound 2.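

The exchange of the 1H-1,2,4-triazol-1-yl group for 1H-tetrazol-1-yl on a saturated chain carbon bound to an aromatic carbon and a saturated ring carbon brings, in this assay, a number 50.7 percentage points lower from compound 1 to compound 3 (beyond the scatter). Among the compounds shown here, this is the first measured change at this place, and it shows that this assay responds strongly to the make-up of this ring, even though the heavy-atom count stays at 5 and only the balance shifts, from 2 carbon and 3 nitrogen to 1 carbon and 4 nitrogen. Nothing at hand accounts for this loss of inhibition.

Going by these compounds, it remains open whether an imidazol-1-yl group or a simple amine at the same carbon would keep or lose inhibition. On these data alone, it is equally open whether the methyl on the aromatic carbon, as in compound 2, would raise the number alongside 1H-tetrazol-1-yl.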